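From Methoxy to Hydroxy: Estimating Compound 4

The source may report more compounds than this note shows. Statements on the series, on what has been measured and on what is new or still open speak of the compounds shown alone.

Three compounds sharing one core were tested in a functional assay on SN12C cells (Homo sapiens) for cytotoxicity, read by sulforhodamine B assay, with a stated time of 48 h, tested at 1 uM; on this read-out higher numbers stand for a weaker effect at the one concentration tested and lower numbers for a stronger effect. Compound 1 `COc1cc(C)cc(-c2nn(CC#N)cc2-c2ccc(-c3cccc(C(C)=O)c3)nc2)c1` gives 39%, compound 2 `Cc1cc(O)cc(-c2nn(CC#N)cc2-c2ccnc(-c3ccc(Oc4ccccc4)cc3)c2)c1` gives -57%, and compound 3 `COc1cc(C)cc(-c2nn(CC#N)cc2-c2ccnc(-c3ccc(N(C)C)cc3)c2)c1` gives 8%. Compound 3 thus stands second highest of the three, with compound 1 above it beyond the scatter and compound 2 far below it, also beyond the scatter. Compound 4 `Cc1cc(O)cc(-c2nn(CC#N)cc2-c2ccnc(-c3ccc(N(C)C)cc3)c2)c1` differs from compound 3 in one place: hydrogen in place of methyl on an oxygen on an aromatic ring. Among the measured compounds shown here, no pair differing only in this way has been measured, so the size of the step is open; compound 2, which carries the hydroxy, sits lowest, but it also differs elsewhere. A modest downward step is expected, a number 16 percentage points lower from compound 3 to compound 4 (beyond the scatter), giving compound 4 an estimated -8% in this assay, between -45% and 30%.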

Compound 4, a percentage reported as activity, at one concentration (the size of the read-out at that concentration, not a potency): 26%
Beside the measured number, compound 4's estimate is 34 percentage points below it; low and high end bracket the measured number.
By their numbers in this assay, from the lowest: compound 2; then compound 3; then compound 4; then compound 1.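

In this assay, hydroxy in place of methoxy on the aromatic ring gives a number 18 percentage points higher from compound 3 to compound 4 (beyond the scatter), so in this one pair the change brings a weaker effect. With the hydroxy kept, dimethylamino in place of phenoxy gives a number 83 percentage points higher from compound 2 to compound 4 (beyond the scatter), so the hydroxy alone does not carry the low number of compound 2. Nothing available gives a cause for either step. On these data alone, whether an ethyl group or a longer chain on that oxygen, or an amine in place of it, would fall on the same scale stays open. So does whether methoxy to hydroxy runs the same way when phenoxy is present.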